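A Dimethylamino Swap on a Nitro-Bearing Sulfonamide

This account rests on a few compounds, and the source may have more. Where it says the series, first, only, none or still open, it means among the compounds named here.

The compounds share one core, and they differ only in the groups on the aromatic ring that carries the sulfonyl. Compound 1, `Cc1ccc(N)cc1S(=O)(=O)N(C)/N=C/c1cnn2ccc(C#N)cc12`, was tested in an assay on isolated protein for inhibition of phosphatidylinositol 4,5-bisphosphate 3-kinase catalytic subunit beta isoform (Homo sapiens), read by 33P incorporation, with a stated time of 60 min; on this read-out lower numbers stand for stronger inhibition and higher numbers for weaker inhibition. Compound 1 returns only a limit of the assay, > 1000 nM, not a number. Compound 2, `Cc1ccc(C)c(S(=O)(=O)N(C)/N=C/c2cnn3ccc(C#N)cc23)c1`, likewise gives only a limit in this assay, > 1000 nM. Because the limit of > 1000 nM in this assay, at which 2 of the 3 values shown sit, the step that the two limits leave unreadable from compound 1 to compound 2 has no readable size. Among the compounds with values here, compound 3, `CN(/N=C/c1cnn2ccc(C#N)cc12)S(=O)(=O)c1cc([N+](=O)[O-])ccc1F`, is the only compound that yields a number in this assay, namely 44 nM. Compound 4, `CN(C)c1ccc([N+](=O)[O-])cc1S(=O)(=O)N(C)/N=C/c1cnn2ccc(C#N)cc12`, has not yet been tested. It differs from compound 3 by dimethylamino in place of fluoro on an aromatic carbon. Within the data shown here, no measured step bears on this change: the single step that exists, between compound 1 and compound 2, is unreadable, so there is nothing to set a direction or a size. The step of a 1.4-fold higher number from compound 3 to compound 4 (0.13 log units; within the scatter) in this assay is therefore expected to stay within the usual scatter, with a wide margin of uncertainty. Compound 4 is estimated at 60 nM in this assay, within a range from 15 nM to 300 nM.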

Compound 4, half-maximal inhibitory concentration: 44 nM
Estimate against measurement, compound 4: 1.4-fold (0.13 log units) above; measured number inside the range.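

In this assay, dimethylamino in place of fluoro gives no change at the digits printed from compound 3 to compound 4 (within the scatter). This is the only readable step among the compounds shown, and it is the first information about this aromatic carbon, which lies ortho to a large group and para to a nitro group. Here the read-out does not separate a fluoro of 1 heavy atom with 0 hydrogen-bond acceptors from a dimethylamino of 3 heavy atoms with 1 hydrogen-bond acceptor, so for this one pair, the larger group costs nothing measurable.

On these data alone, whether that holds for other groups at this carbon remains open, such as a methoxy group, a plain amine or a morpholine ring, and so does whether the same swap would read alike with the nitro group replaced by a nitrile or an amine. The step from compound 1 to compound 2 cannot be read and adds nothing on these questions, because both compounds return only a limit of the assay: the limit of > 1000 nM in this assay, at which 2 of the 4 values shown sit.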